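This account rests on a few compounds, and the source may have more. Where it says the series, first, only, none or still open, it means among the compounds named here.

Of the compounds shown here, three built on a shared core have been tested in an ADME assay on HT-29 cells (Homo sapiens) for cytotoxicity, read by MTT assay, with a stated time of 72 h; a higher number here means a weaker inhibitor, a lower number a stronger inhibitor. In this assay compound 1 `C=CC(=O)Nc1cc(Nc2ncc3ncn(-c4ccc(Cl)cc4)c3n2)c(OC)cc1N(C)CCN(C)C` gives 7690 nM. For the measured compounds named here, compound 2 `C=CC(=O)Nc1cc(Nc2ncc3ncn(-c4ccccc4F)c3n2)c(OC)cc1N(C)CCN(C)C` gives 9750 nM, and the change of a 1.3-fold higher number from compound 1 to compound 2 (0.10 log units; within the scatter) is the only one-place step measured so far. Compound 3 `C=CC(=O)Nc1cc(Nc2ncc3nc(Nc4ccccc4)n(C)c3n2)c(OC)cc1N(C)CCN(C)C` gives 8700 nM, the second highest of the three numbers, within the scatter of both compound 1 and compound 2. Compound 4 `C=CC(=O)Nc1cc(Nc2ncc3nc(Nc4ccccc4)n(C4CCCC4)c3n2)c(OC)cc1N(C)CCN(C)C` differs from compound 3 by cyclopentyl in place of methyl on an aromatic nitrogen. Going by the values given here, the one measured step, a 1.3-fold higher number from compound 1 to compound 2 (0.10 log units; within the scatter), concerns a different position and was within the scatter, so nothing in the data points to a step beyond the scatter in this assay. Compound 4 is therefore expected to give about 8000 nM, within a range from 3500 nM to 18000 nM. That amounts to an expected step of a 1.1-fold lower number from compound 3 to compound 4 (0.04 log units; within the scatter).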

Compound 4, half-maximal inhibitory concentration: 11400 nM
Beside the measured number, compound 4's estimate is 1.4-fold (0.15 log units) below it; the measured number falls inside the stated range.
By their numbers in this assay, from the lowest: compounds 1, 3, 2 and 4 (each within the scatter of the next).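

Cyclopentyl in place of methyl on an aromatic nitrogen gives a 1.3-fold higher number from compound 3 to compound 4 (0.12 log units; within the scatter) in this assay, the first reading at this position. With the anilino group held in place, a five-membered carbon ring and a methyl group on this nitrogen therefore stay within the scatter of each other. No evidence is given that could explain this result. From the compounds shown here alone, whether a longer chain ending in an amine or a carboxylic acid on this nitrogen would also stay within the scatter remains open, as does whether cyclopentyl behaves the same way without the anilino group.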